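Half-lives of Small Electrophiles in Buffer

The compounds below may be only part of what the source reports. "The series", "measured", "known", "first", "only" and "open" are said of these compounds alone.

Measured compounds:
- compound 1, `C=CS(=O)(=O)c1cc(C(F)(F)F)cc(C(F)(F)F)c1`, < 0.017 h
- compound 2, `C=Cc1cc(C(F)(F)F)cc(C(F)(F)F)c1`, > 50 h
- compound 3, `C#Cc1cc(C(F)(F)F)cc(C(F)(F)F)c1`, 0.3 h

These three compounds share one core and differ only in the group on the ring. Going by the values given here, in an ADME assay for pharmacokinetics, read by LC-MS, in phosphate buffer, with a stated time of 72 h, at pH 7.4, tested at 250 uM (a lower number here means that the compound disappears faster, a higher number that the compound lasts longer), compound 3 gives 0.3 h, and this is the only plain number among the three. For compound 1 the value of < 0.017 h is a limit of the assay, not a number (the limit of < 0.017 h in this assay, at which 1 of the 3 values shown sits). For compound 2 the value of > 50 h is likewise a limit (the limit of > 50 h in this assay, at which 1 of the 3 values shown sits). The steps are large: an at least 17-fold higher number from compound 1 to compound 3 (1.24 log units; beyond the scatter), and an at least 160-fold lower number from compound 2 to compound 3 (2.22 log units; beyond the scatter), so compound 3 sits between the two limits.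

Compound 4, `O=C(CBr)c1cc(C(F)(F)F)cc(C(F)(F)F)c1`, has not yet been measured. It differs from compound 3 in one place: (bromomethyl)carbonyl in place of ethynyl on an aromatic carbon. Among the compounds with values here, none of the measured steps swaps in this group, so none bears on it directly; they only show that changing the group on this ring can shift the half-life by large amounts in either direction. The best guide is the modest value of compound 3 in this assay, with wide uncertainty. For compound 4 the estimate is 0.5 h, with a range from 0.05 h to 5 h, which would mean a step of a 1.7-fold higher number from compound 3 to compound 4 (0.22 log units; within the scatter) expected from compound 3.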

Compound 4, half-life: < 0.017 h
Compound 4 gave a limit, no number (the forecaster's own chance of this, stated with the estimate: 15%); middle value at least 29-fold (1.46 log units) from the limit.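

In this assay the (bromomethyl)carbonyl group on this aromatic carbon takes compound 4 to the lower end of what can be read, and its result is a limit and not a number: the limit of < 0.017 h in this assay, at which 2 of the 4 values shown sit.

Putting this group in place of ethynyl gives an at least 17-fold lower number from compound 3 to compound 4 (1.24 log units; beyond the scatter), while putting it in place of vinyl gives an at least 2900-fold lower number from compound 2 to compound 4 (3.46 log units; beyond the scatter). Going by these compounds alone, this shows that vinylsulfonyl is not the only group on the shared core that reaches this limit, since a group built on a carbonyl and a bromine reaches it too, although compound 1 and compound 4 both stand at limits, so the step between them cannot be read.

On these data alone, the actual half-lives of compound 1 and compound 4 stay unknown, and so does any order between them, as does what either compound turns into in the buffer. Also open, as far as these compounds go, is how much of the result for compound 4 rests on the bromine, which the same core carrying a chloromethyl carbonyl group or a plain acetyl group would help to settle.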